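A Fluoro Step on the Shared Core of Compound 3

The source may hold more compounds than are shown below. What is called first, only, known or untested is meant among the compounds shown, and "the series" means these compounds.

Three compounds built on a shared core have been examined so far in a physicochemical assay for acid dissociation, read by capillary electrophoresis. Compound 3 `CC1(c2cc(NC(=O)c3ccc(C#N)cn3)ccc2F)Cc2cnccc2C(N)=N1` gives 9, the higher of the two numbers available. Compound 1 `CC1(c2cc(NC(=O)c3ccc(C#N)cn3)ccc2F)Cc2c(F)cncc2C(N)=N1` gives 7.6, and this gap to compound 3 lies beyond the scatter. For compound 2 `CC1(c2cc(NC(=O)c3ccc(C#N)cn3)ccc2F)Cc2c(ccnc2F)C(N)=N1` the entry reads "not determined" (no result reported), so it offers no number to compare.

The next compound to be measured is compound 4 `CC1(c2cc(NC(=O)c3ccc(C#N)cn3)ccc2F)Cc2cncc(F)c2C(N)=N1`. It departs from compound 3 by one change: fluoro in place of hydrogen on an aromatic carbon. This places fluoro in place of hydrogen on an aromatic carbon, two atoms from the ring nitrogen.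

Within the data shown here, no measured pair of compounds differs in a single place, so no direct step is available as a guide. Among the measured compounds shown here, the expectation therefore leans on compound 1 at 7.6, the only number that stands well away from compound 3 in this assay. The estimated change a number 1.50 log units lower from compound 3 to compound 4 (beyond the scatter) is a fall beyond the scatter, of about the size of the gap already seen. For compound 4 the expected value is 7.5, with an estimated range from 6.8 to 8.3.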

Compound 4, acid dissociation constant: 7.3
The estimate for compound 4 lay 0.20 log units above the measured number, within the range that was stated.
By their numbers in this assay, from the lowest: compounds 4 and 1 (each within the scatter of the next); then compound 3.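

In this assay, the change of fluoro in place of hydrogen on an aromatic carbon, two atoms from the ring nitrogen, gives a number 1.70 log units lower from compound 3 to compound 4 (beyond the scatter), a large step. Among these compounds, this is the first reading of what a single change does on the shared core, since the earlier compounds offered no pair differing in one place. It shows that this aromatic carbon is not a silent site in this read-out: the exchange of one hydrogen atom for one fluorine atom is enough to carry the number well past the usual scatter, and the direction of that movement is downward. The data shown offer no independent measurement that would account for the size of this step.

From the compounds shown here alone, what stays open is whether the step belongs to fluoro itself or would also appear with another group on the same aromatic carbon, such as chloro, methoxy, an amine or a nitrile. A single pair also cannot tell whether the same exchange would give a step of similar size on a core carrying a different amide partner, such as a simple phenyl amide.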